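This account rests on a few compounds, and the source may have more. Where it says the series, first, only, none or still open, it means among the compounds named here.

Compound 1 `CCN(CC)C(=O)Oc1ccc2cccnc2c1-c1cccc2cccnc12` carries a diethylcarbamoyl on an oxygen of its core. In an ADME assay on TZM cells (Homo sapiens) for cytotoxicity, read by MTT assay, with a stated time of 48 h (on this read-out higher numbers stand for lower toxicity in this test and lower numbers for higher toxicity in this test), compound 1 is reported as "not toxic" (no number reported), and no single number stands behind that entry. Compound 2 `CCN(CC)C(=O)Oc1ccc2ccccc2c1-c1cccc2cccnc12` carries the same group on the same kind of oxygen but on a different core; in this assay compound 2 gives 69300 nM. For the measured compounds named here, no step between compound 1 and compound 2 is counted here, so the two entries show only that both sit at the weakly toxic end of the read-out, one of them without a figure. Compound 3 `CC(C)Oc1ccc2cccnc2c1-c1cccc2cccnc12` has not been measured. The change from compound 1 to compound 3 is isopropyl in place of diethylcarbamoyl on an oxygen on an aromatic ring. Going by the values given here, no measured pair traces this change, so its size in this assay is open; the expectation is for no move beyond the scatter, compound 3 staying weakly toxic as compound 1 is, with a real chance that only a limit and no number is reported. Compound 3 is estimated at 70000 nM, with a range from 30000 nM to 150000 nM.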

Compound 3, half-maximal cytotoxic concentration: "not toxic" (no number reported)
For compound 3 the study gives words and no number; the estimate stays without a comparison.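

In this assay, for the compounds shown here, compound 3 is entered as "not toxic" (no number reported) and compound 1 as "not toxic" (no number reported) and so no step between compound 1 and compound 3 can be read. The compounds shown leave open how far, if at all, isopropyl in place of diethylcarbamoyl shifts this read-out. No evidence shown bears on this result.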